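From 3-isopropylphenyl to 4-(tert-butyl)phenyl on a shared core

The source may report more compounds than this note shows. Statements on the series, on what has been measured and on what is new or still open speak of the compounds shown alone.

In a functional assay on MDA-MB-231 cells (Homo sapiens) for inhibition, read by CCK-8 assay, with a stated time of 48 h (on this read-out lower numbers stand for stronger inhibition of growth and higher numbers for weaker inhibition of growth), compound 1 `Cc1cccc(Nc2nc(Nc3ccc(N4CCN(C)CC4)cn3)ncc2Cl)c1` gives 5270 nM and compound 2 `CC(C)c1cccc(Nc2nc(Nc3ccc(N4CCN(C)CC4)cn3)ncc2Cl)c1` gives 5590 nM, so these two values lie within the usual scatter of each other. Compound 3 `CN1CCN(c2ccc(Nc3ncc(Cl)c(Nc4ccc(C(C)(C)C)cc4)n3)nc2)CC1` awaits measurement. It carries 4-(tert-butyl)phenyl in place of 3-isopropylphenyl on a nitrogen on an aromatic ring, the difference being (4-(tert-butyl)phenyl in place of 3-isopropylphenyl on a nitrogen on an aromatic ring). Among the measured compounds shown here, only one measured step bears on this change: isopropyl in place of methyl on an aromatic carbon gave a 1.1-fold higher number from compound 1 to compound 2 (0.03 log units; within the scatter). For the measured compounds named here, that small step offers a modest guide, since no measured compound carries 4-(tert-butyl)phenyl. No change beyond the scatter is therefore expected in this assay, in either direction. The expected step is a 1.1-fold lower number from compound 2 to compound 3 (0.05 log units; within the scatter). For compound 3 the estimated value is 5000 nM, with an expected range from 2000 nM to 12000 nM.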

Compound 3, concentration for 50% growth inhibition: 16200 nM
Compound 3: middle estimate off by 3.2-fold (0.51 log units), on the low side, and the stated range ends below it.
By their numbers in this assay, from the lowest: compounds 1 and 2 (each within the scatter of the next); then compound 3.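

In this assay, the group on a nitrogen on an aromatic ring now proves able to change the result: 4-(tert-butyl)phenyl in place of 3-isopropylphenyl gives a 2.9-fold higher number from compound 2 to compound 3 (0.46 log units; beyond the scatter), a modest shift towards weaker inhibition of growth. The same group in place of 3-methylphenyl gives a 3.1-fold higher number from compound 1 to compound 3 (0.49 log units; beyond the scatter), so compound 3 stands apart from the other two compounds, which lie within the scatter of each other. Nothing measured here explains this shift.

The two group names differ both in the alkyl group and in the number that marks its place, and no pair shown changes only one of these, so the source of the shift remains open. As far as these compounds go, it also remains open how this position would respond to an amine or a carboxylic acid in place of the alkyl group.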